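The source may report more compounds than this note shows. Statements on the series, on what has been measured and on what is new or still open speak of the compounds shown alone.

Compound 1 `C=C(C)CCC[C@]1(C)C2=CCC[C@](C)(C[C@H](OC(C)=O)C3=CC(=O)OC3O)[C@H]2CC[C@H]1C`: 4500 nM
Compound 2 `C=C(C)CC[C@]1(C)C2=CCC[C@](C)(C[C@H](O)c3ccoc3)[C@H]2CC[C@H]1C`: 34000 nM

In a functional assay on A549 cells (Homo sapiens) for antiproliferative activity, read by XTT assay, with a stated time of 72 h (on this read-out higher numbers stand for weaker inhibition and lower numbers for stronger inhibition), compound 1 gives 4500 nM, the lower of the two numbers and so the stronger inhibition. Compound 2 gives 34000 nM, and the gap between these two values lies beyond the scatter.

The next compound to be tested is compound 3 `C=C(C)CCC[C@]1(C)C2=CCC[C@](C)(C[C@@H](OC(C)=O)C3=CC(=O)OC3O)[C@H]2CC[C@H]1C`. Its change from compound 1 is the two compounds have the same atoms and bonds; at least one stereo element is drawn with a configuration in one of them and without one in the other: 1 of 6 stereo elements differ; a stereocentre at a saturated chain carbon is drawn S in compound 1 and R in compound 3: a stereocentre at a saturated chain carbon is drawn S in compound 1 and R in compound 3. The atoms and bonds stay the same.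

Among the measured compounds shown here, no measured pair isolates a change of this kind, so the data offer no direct guide to its size. The expectation therefore stays cautious and starts from the value of compound 1, 4500 nM. The step expected in this assay is small, perhaps none beyond the scatter, with a slight lean toward a higher number, and is estimated as a 1.2-fold higher number from compound 1 to compound 3 (0.09 log units; within the scatter). For compound 3 the estimated value in this assay is 5500 nM, with an expected range of 2200 nM to 14000 nM.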

Compound 3, half-maximal inhibitory concentration: 3200 nM
Compound 3: the middle estimate sits 1.7-fold (0.24 log units) above what was measured; the measured number falls inside the stated range.
By their numbers in this assay, from the lowest: compounds 3 and 1 (each within the scatter of the next); then compound 2.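

In this assay, going from S to R at the saturated chain carbon gives a 1.4-fold lower number from compound 1 to compound 3 (0.15 log units; within the scatter), so the two configurations stand level in this read-out. Among the compounds shown here, this is the first pair that isolates a single stereocentre, and at this position the drawn configuration makes no difference that can be told from the scatter. One caution applies to reading the pair as two cleanly defined configurations: the fact that one of compounds 1 and 3 is drawn with a defined configuration and the other without, at the place where they differ

As far as these compounds go, compound 2 differs from compound 1 in more than one place, so its value adds nothing about this stereocentre, and whether the same lack of preference holds on a different framework stays unknown. From the compounds shown here alone, it also remains open whether the level result survives when the group on this stereocentre is an amine, a carboxylic acid or a longer chain, and whether it holds in any cell line other than the one tested here.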